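Closing an amide ring: from compound 2 to compound 3

A few compounds are considered here, and "the series" means these few. Any claim that something is new, unique, unknown or untested is made for them only; others in the source may bear on it.

This set concerns growth inhibition of colon cancer cells, measured in a functional assay on LoVo cells (Homo sapiens) for antiproliferative activity, read by MTT assay, with a stated time of 72 h; on this read-out lower numbers stand for stronger inhibition and higher numbers for weaker inhibition. Compound 1 `Cn1cc(Nc2nn(Cc3ccc(C(=O)NC4CCCCC4)cc3)c(=O)c3ccccc23)cn1` gives 5300 nM. Among the measured compounds shown here, compound 2 `Cc1noc(C)c1-c1nn(Cc2ccc(C(=O)NC3CCCCC3)cc2)c(=O)c2ccccc12` gives 82200 nM; it stands at the weaker end of the two numbers, and the only measured step, a 16-fold higher number from compound 1 to compound 2 (1.19 log units; beyond the scatter), concerns a group on the shared core, not the amide end of the molecule. Compound 3 `Cc1noc(C)c1-c1nn(Cc2ccc(C(=O)N3CCCCC3)cc2)c(=O)c2ccccc12` differs from compound 2 at that amide end: piperidin-1-yl in place of cyclohexylamino on a carbonyl carbon. For the measured compounds named here, no measured step bears on this particular change, so there is no direct guide to its size or direction. With nothing to point either way, the expected step of a 1.2-fold higher number from compound 2 to compound 3 (0.09 log units; within the scatter) is one within the usual scatter. Compound 3 is therefore estimated at 100000 nM, with a plausible range from 30000 nM to 300000 nM, and a real chance that the assay reports only a limit.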

Compound 3, half-maximal inhibitory concentration: > 100000 nM
Compound 3 gave a limit, no number (the forecaster's own chance of this, stated with the estimate: 30%); the middle value lies on the limit itself.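

In this assay compound 3 gives > 100000 nM, which is a limit of the assay and not a number. Among the compounds shown here, the step, an at least 1.2-fold higher number from compound 2 to compound 3 (0.08 log units; that floor lies within the scatter), is the first reading at the amide end of the molecule, where cyclohexylamino, with its amide hydrogen, gives way to piperidin-1-yl, which has no hydrogen-bond donor; its floor alone does not show whether this swap changes activity, and the true step may be larger. What can be read here stops at that limit: the limit of > 100000 nM in this assay, at which 1 of the 3 values shown sits.

The compounds shown leave open whether the same swap would matter on compound 1, which carries (1-methyl-1H-pyrazol-4-yl)amino on the shared core and has a measured number to start from. They also leave open what dimethylamino or morpholin-4-yl would do on the same carbonyl carbon.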